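Propyl on the ring nitrogen of the shared core

The source may report more compounds than this note shows. Statements on the series, on what has been measured and on what is new or still open speak of the compounds shown alone.

Among the measured compounds shown here, compound 3 `Nc1nc(N)c2nc(O)n(Cc3ccccc3)c2n1` carries the highest number of the three measured members: in a functional assay (spleen, spleen) for activation, with Mus musculus as the target (a higher number here means that more compound is needed for the effect, a lower number that less compound is needed), compound 3 gives 10 uM, whereas compound 1 `CNc1nc(N)c2nc(O)n(Cc3ccccc3)c2n1` gives 1 uM and compound 2 `CCc1nc(N)c2nc(O)n(Cc3ccccc3)c2n1` gives 1 uM. The step of a 10-fold higher number from compound 1 to compound 3 (1.00 log units; beyond the scatter) and the step of a 10-fold higher number from compound 2 to compound 3 (1.00 log units; beyond the scatter) both lie beyond the scatter, while between the other two there is no change at the digits printed from compound 1 to compound 2 (within the scatter).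

Compound 4 `CCCNc1nc(N)c2nc(O)n(Cc3ccccc3)c2n1` differs from compound 3 by propyl in place of hydrogen on a nitrogen on an aromatic ring. For the measured compounds named here, the closest precedent is the reverse of the step of a 10-fold higher number from compound 1 to compound 3 (1.00 log units; beyond the scatter); the step of a 10-fold higher number from compound 2 to compound 3 (1.00 log units; beyond the scatter) runs the same way but at another place. Compound 4 is therefore expected to give a lower number, a step of about a 10-fold lower number from compound 3 to compound 4 (1.00 log units; beyond the scatter). The estimate for compound 4 is 1 uM, expected to fall between 0.3 uM and 3 uM.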

Compound 4, minimum effective concentration: 0.1 uM
Compound 4: the middle estimate sits 10-fold (1.00 log units) above what was measured, and the stated range ends above it.
By their numbers in this assay, from the lowest: compound 4; then compounds 1 and 2 (each within the scatter of the next); then compound 3.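

In this assay, propyl on this nitrogen goes well beyond what the smaller substituent reached, with a 100-fold lower number from compound 3 to compound 4 (2.00 log units; beyond the scatter), and further than methyl on the same nitrogen, with a 10-fold lower number from compound 1 to compound 4 (1.00 log units; beyond the scatter). Ethyl in place of the whole propylamino group falls short as well, with a 10-fold lower number from compound 2 to compound 4 (1.00 log units; beyond the scatter). Across hydrogen, methyl and propyl on this nitrogen (compound 3, compound 1, compound 4) the number falls with each larger chain, and none of the three goes against this; no measurement here bears on why.

On these data alone, whether a longer chain such as butyl or pentyl lowers the number further remains open. So does whether a branched isopropyl group on this nitrogen matches propyl.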